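The source may hold more compounds than are shown below. What is called first, only, known or untested is meant among the compounds shown, and "the series" means these compounds.

Measured compounds in a functional assay on DU-145 cells (Homo sapiens) for cytotoxicity, read by sulforhodamine B assay, with a stated time of 48 h; a higher number here means a weaker inhibitor, a lower number a stronger inhibitor:
compound 1, `CC(=O)OC[C@H]1O[C@@H](n2cc(CN3C(=O)/C(=C/c4ccc(C)cc4)c4ccccc43)nn2)[C@H](OC(C)=O)[C@@H](OC(C)=O)[C@@H]1OC(C)=O`, gives 9300 nM
compound 2, `CC(=O)OC[C@H]1O[C@@H](n2cc(CN3C(=O)/C(=C\C=C\c4ccccc4)c4ccccc43)nn2)[C@H](OC(C)=O)[C@@H](OC(C)=O)[C@@H]1OC(C)=O`, gives 19500 nM
compound 3, `CC(=O)OC[C@H]1O[C@@H](n2cc(CN3C(=O)/C(=C/C=C/c4ccccc4)c4ccccc43)nn2)[C@H](OC(C)=O)[C@@H](OC(C)=O)[C@@H]1OC(C)=O`, gives 17100 nM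

Compound 2 and compound 3 lie within the scatter of each other; their only difference is the drawn configuration of one double bond, and the step of a 1.1-fold lower number from compound 2 to compound 3 (0.06 log units; within the scatter) is accordingly small (the fact that compounds 2 and 3 differ only in the configuration as drawn). Compound 1 sits further off, beyond the scatter from compound 2, with the lower number of the two.

Compound 4, `CC(=O)OC[C@H]1O[C@@H](n2cc(CN3C(=O)/C(=C\c4ccco4)c4ccccc43)nn2)[C@H](OC(C)=O)[C@@H](OC(C)=O)[C@@H]1OC(C)=O`, has not yet been measured. It differs from compound 2 by furan-2-yl in place of 2-phenylethenyl on a double-bonded chain carbon bound to a double-bonded ring carbon. The closest measured step is a 1.8-fold higher number from compound 1 to compound 3 (0.26 log units; within the scatter), where a single aromatic ring on that same chain carbon was exchanged for the longer two-ring-less chain, and this stayed within the scatter. The configuration step from compound 2 to compound 3 is also small. Taken together, the expected change from compound 2 to compound 4 is modest, if anything a somewhat lower number, in line with compound 1 carrying a single ring directly on that carbon; the step expected is a 1.6-fold lower number from compound 2 to compound 4 (0.21 log units; within the scatter). Compound 4 is therefore estimated at 12000 nM in this assay, with a range from 4000 nM to 35000 nM.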

Compound 4, half-maximal inhibitory concentration: 16900 nM
Estimate against measurement, compound 4: 1.4-fold (0.15 log units) below, and the stated range covers the measured number.
By their numbers in this assay, from the lowest: compounds 1, 4, 3 and 2 (each within the scatter of the next, the first and the last beyond it).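

For the compounds shown here, on a double-bonded chain carbon bound to a double-bonded ring carbon, the earlier compounds carried only all-carbon groups; in this assay, furan-2-yl in place of 2-phenylethenyl gives a 1.2-fold lower number from compound 2 to compound 4 (0.06 log units; within the scatter), a step that stays within the scatter. This place therefore accepts the loss of the double bond outside the aromatic ring, a drop from 8 heavy atoms to 5, and the arrival of a ring oxygen, all in one exchange, with no readable change in the number. Nothing in the information given accounts for why this exchange leaves the number where it is.

The compounds shown leave open whether an amine or a carboxylic acid on this carbon would move the number beyond the scatter. They also leave open whether a thiophene-2-yl ring would behave like furan-2-yl.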